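A few compounds are considered here, and "the series" means these few. Any claim that something is new, unique, unknown or untested is made for them only; others in the source may bear on it.

Of the compounds shown here, three sharing one core have been measured in an assay for binding affinity to 5-hydroxytryptamine receptor 1F (Homo sapiens), read by radioligand binding; a lower number here means a stronger inhibitor, a higher number a weaker inhibitor. Compound 1 `CCCCCC(=O)Nc1ccc2[nH]cc(C3CCN(C)CC3)c2n1` gives 13 nM in this assay and stands second highest of the three numbers, with compound 2 nearest and compound 3 furthest. Compound 2 `CN1CCC(c2c[nH]c3ccc(NC(=O)c4cccc(F)c4)nc23)CC1` gives 11 nM in this assay, and the step of a 1.2-fold lower number from compound 1 to compound 2 (0.07 log units; within the scatter) lies within the scatter. Compound 3 `CN1CCC(c2c[nH]c3ccc(NC(=O)C(C)(C)C)nc23)CC1` gives 62 nM in this assay; the step of a 4.8-fold higher number from compound 1 to compound 3 (0.68 log units; beyond the scatter) is modest but beyond the scatter, and the step of a 5.6-fold higher number from compound 2 to compound 3 (0.75 log units; beyond the scatter) matches it.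

Compound 4 `CN1CCC(c2c[nH]c3ccc(NC(=O)Nc4ccc(F)cc4)nc23)CC1` has not yet been measured. It differs from compound 1 as follows: (4-fluorophenyl)amino in place of pentyl on a carbonyl carbon. The measured steps that bear on this are the step from compound 1 to compound 2, where an aromatic group replaced the pentyl with no change beyond the scatter, and the step from compound 1 to compound 3, where a branched alkyl replaced it and the number rose modestly. Going by the values given here, no measured pair carries an amino group on the carbonyl carbon, so the effect of that part of the change is untested. The expectation for compound 4 is therefore a step of a 1.4-fold higher number from compound 1 to compound 4 (0.14 log units; within the scatter) that stays within the scatter, with widened uncertainty. Compound 4 is estimated at 18 nM, with a range from 5 nM to 70 nM in this assay.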

Compound 4, inhibition constant: 11 nM
Estimate against measurement, compound 4: 1.6-fold (0.21 log units) above; the measured number falls inside the stated range.
By their numbers in this assay, from the lowest: compounds 2, 4 and 1 (each within the scatter of the next); then compound 3.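

At the carbonyl carbon, the first group joined through an amino nitrogen, (4-fluorophenyl)amino, brings a hydrogen-bond donor that pentyl lacks, yet in this assay the result is a 1.2-fold lower number from compound 1 to compound 4 (0.07 log units; within the scatter), and replacing 3-fluorophenyl gives no change at the digits printed from compound 2 to compound 4 (within the scatter). This position therefore accommodates a pentyl chain, a directly attached fluorophenyl ring and an amino-linked fluorophenyl ring with no difference beyond the scatter, while tert-butyl is the one group among these four that stands apart, as a 5.6-fold lower number from compound 3 to compound 4 (0.75 log units; beyond the scatter) shows. Nothing available explains why these groups fall together or why tert-butyl differs.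

The compounds shown do not separate the effect of the amino nitrogen from that of the fluorine or its place on the ring, so unsubstituted phenylamino and (3-fluorophenyl)amino would be needed to tell those contributions apart. They also leave open whether the tolerance extends to a small alkylamino group such as methylamino, to an ethoxy group on the carbonyl carbon, or to a longer chain than pentyl, and they say nothing about selectivity over other receptors.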